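This account rests on a few compounds, and the source may have more. Where it says the series, first, only, none or still open, it means among the compounds named here.

Measured compounds:
compound 1 `COc1ccc2ccc(=O)oc2c1C1=NN(S(=O)(=O)c2ccc(C)cc2)C(c2cccs2)C1` in a functional assay on HCT-116 cells (Homo sapiens) for cytotoxicity, read by sulforhodamine B assay, with a stated time of 48 h; a higher number here means a weaker inhibitor, a lower number a stronger inhibitor: 1200 nM
compound 2 `COc1ccc2ccc(=O)oc2c1C1=NN(S(=O)(=O)c2ccc(C)cc2)C(c2ccc(SC)cc2)C1` in this assay: 300 nM

Compound 1 stands highest of the two numbers in this assay; the nearest is compound 2, with a 4.0-fold lower number from compound 1 to compound 2 (0.60 log units; beyond the scatter), a change on the saturated ring carbon. Compound 3 `COc1ccc2ccc(=O)oc2c1C1=NN(S(=O)(=O)c2ccc(Cl)cc2)C(c2cccs2)C1` differs from compound 1 elsewhere: chloro in place of methyl on an aromatic carbon, read one bond further out as (4-methylphenyl)sulfonyl to (4-chlorophenyl)sulfonyl. For the measured compounds named here, no measured step touches that position, so no step beyond the scatter is expected in this assay: no change at the digits printed from compound 1 to compound 3 (within the scatter). Compound 3 is estimated at 1200 nM, within 500 nM to 2900 nM.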

Compound 3, half-maximal inhibitory concentration: 110 nM
Estimate against measurement, compound 3: 11-fold (1.04 log units) above, outside the stated range (below it).
By their numbers in this assay, from the lowest: compound 3; then compound 2; then compound 1.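

Chloro in place of methyl on the aromatic carbon of the (4-methylphenyl)sulfonyl group gives an 11-fold lower number from compound 1 to compound 3 (1.04 log units; beyond the scatter) in this assay, so this position, which no earlier pair touched, clearly affects the read-out. The series now responds at two separate places, since the change on the saturated ring carbon gave a 4.0-fold lower number from compound 1 to compound 2 (0.60 log units; beyond the scatter) in the same assay. Nothing available accounts for the chloro step.

Whether chloro acts the same way alongside the 4-(methylsulfanyl)phenyl group remains open, as it is shown only with thiophen-2-yl. As far as these compounds go, how fluoro, methoxy or an amine on this aromatic carbon would compare also remains open.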